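This account rests on a few compounds, and the source may have more. Where it says the series, first, only, none or still open, it means among the compounds named here.

Measured in an ADME assay on Vero cells (Chlorocebus sabaeus) for inhibition; a lower number here means that less compound is tolerated, a higher number that more compound is tolerated:
- compound 1 `COc1ccc(/C=C2\CCC/C(=C\c3ccc(Cl)cc3)C2=O)cc1` gives 401000 nM
- compound 2 `COc1cccc(/C=C2\CCC/C(=C\c3ccccc3)C2=O)c1OC` gives 33500 nM
- compound 3 `COc1cccc(/C=C2\CCC/C(=C\c3ccc(Br)cc3)C2=O)c1OC` gives 31500 nM

Compound 3 lies within the scatter of compound 2, and compound 1 stands well clear of both with a higher number. The next structure is compound 4 `COc1cccc(/C=C2\CCC/C(=C\c3ccc([N+](=O)[O-])cc3)C2=O)c1OC`, which carries nitro in place of bromo on an aromatic carbon, para to a large group: nitro in place of bromo on an aromatic carbon.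

Among the compounds with values here, only one measured step bears on this place: a 1.1-fold lower number from compound 2 to compound 3 (0.03 log units; within the scatter), with bromo in place of hydrogen, and it stays within the scatter. Compound 1 differs from compound 3 in more than one place, so it isolates nothing here. Within the data shown here, no measured compound carries nitro, so the evidence is thin. With that single step as the guide, no change beyond the scatter is expected in this assay, though the range is kept wide. The estimated step is a 1.1-fold lower number from compound 3 to compound 4 (0.02 log units; within the scatter). Compound 4 is estimated at 30000 nM, with an expected range of 10000 nM to 90000 nM.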

Compound 4, half-maximal cytotoxic concentration: < 10000 nM
Compound 4: a limit, no number; the forecaster's own chance of this, stated with the estimate: 5%; middle value at least 3.0-fold (0.47 log units) from the limit.
By their numbers in this assay, from the lowest: compounds 3 and 2 (each within the scatter of the next); then compound 1. At a limit, below all of these: compound 4.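

In this assay, this position is no longer silent: hydrogen and bromo gave a 1.1-fold lower number from compound 2 to compound 3 (0.03 log units; within the scatter), whereas nitro gives an at least 3.1-fold lower number from compound 3 to compound 4 (0.49 log units; beyond the scatter), and the comparison with the unsubstituted ring reads the same way, an at least 3.3-fold lower number from compound 2 to compound 4 (0.52 log units; beyond the scatter). On this evidence, the group on this aromatic carbon, para to a large group, can matter for the tolerated concentration, with the 4-bromophenyl to 4-nitrophenyl change moving the number beyond the scatter. Compound 4 has a limit and not a number, so both steps are lower bounds: the limit of < 10000 nM in this assay, at which 1 of the 4 values shown sits.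

Going by these compounds, how far compound 4 lies under its limit remains open, and with it the true size of the nitro step. Also open, on these data alone, is whether the shift is confined to nitro or extends to an amine, a carboxylic acid or a nitrile at this place.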